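The compounds below may be only part of what the source reports. "The series", "measured", "known", "first", "only" and "open" are said of these compounds alone.

Measured in a functional assay on brain (Rattus norvegicus, strain Wistar) for inhibition; on this read-out lower numbers stand for stronger inhibition and higher numbers for weaker inhibition:

Compound 1 `Cc1[nH]c(=O)n(C)c1-c1ccc(C(C)(C)C)cc1`: 8400 nM
Compound 2 `CCCCCCCCCCc1ccc(-c2c(C)[nH]c(=O)n2C)cc1`: 7900 nM
Compound 3 `CCCCCCCCCCCCCCCCCCOc1ccc(-c2c(C)[nH]c(=O)n2C)cc1`: > 100000 nM (a limit of the assay, not a number)

Only two of these three results are actual numbers. Compound 1 gives 8400 nM and compound 2 gives 7900 nM, and these two values lie within the usual scatter of each other. Among the measured compounds shown here, compound 1 therefore sits level with the only other compound that has a true number. Compound 3 gives > 100000 nM, which is a limit of the assay.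

The next compound to be tested is compound 4 `Cc1[nH]c(=O)n(C)c1-c1ccc(-c2ccccc2)cc1`. It keeps the shared core of compound 1 but carries phenyl in place of tert-butyl on an aromatic carbon.

For the measured compounds named here, no measured pair shows this exact change, so any expectation here is only a rough one. The closest guide is that compound 1 at 8400 nM and compound 2, with its decyl chain, at 7900 nM do not differ beyond the scatter, even though their groups differ. In this assay, a step beyond the scatter in either direction is therefore not expected. The estimated change is a 1.1-fold higher number from compound 1 to compound 4 (0.03 log units; within the scatter), which is expected to stay within the scatter. For compound 4 the estimated value is 9000 nM, with an expected range from 2500 nM to 30000 nM.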

Compound 4, half-maximal inhibitory concentration: 6300 nM
The estimate for compound 4 lay 1.4-fold (0.15 log units) above the measured number, within the range that was stated.
By their numbers in this assay, from the lowest: compounds 4, 2 and 1 (each within the scatter of the next). At a limit, above all of these: compound 3.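

In this assay, the first step read directly at this position is a 1.3-fold lower number from compound 1 to compound 4 (0.12 log units; within the scatter), and it lies within the scatter, so phenyl and tert-butyl cannot be told apart here. The position on the aromatic carbon, para to a group of 8 heavy atoms, therefore accepts a group with one six-membered aromatic ring as well as a group with no ring, without a measurable change in the read-out. Phenyl brings 6 heavy atoms where tert-butyl has 4, yet neither group has hydrogen-bond donors, hydrogen-bond acceptors or a net charge, so this pair tests only one carbon group against another.

Going by these compounds, whether an amine or a carboxylic acid at this position would shift the number beyond the scatter remains open, because both groups in this pair contain only carbon. Also open is where compound 3, with its long chain joined through oxygen, truly stands, since its result is a limit and not a number: the limit of > 100000 nM in this assay, at which 1 of the 4 values shown sits.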